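Replacing the Thiophene Arm of Compound 2

The compounds below may be only part of what the source reports. "The series", "measured", "known", "first", "only" and "open" are said of these compounds alone.

Compound 2 `Cc1ccc(/C=C(\C(=O)c2ccc(Cl)cc2)S(=O)(=O)Cc2ccc(Cl)cc2)s1` stands as the strongest growth inhibitor of the three measured compounds in a functional assay on DU-145 cells (Homo sapiens) for inhibition, read by trypan blue exclusion, with a stated time of 96 h (a higher number here means a weaker inhibitor of growth, a lower number a stronger inhibitor of growth), where compound 2 gives 1000 nM. Compound 1 `Cc1ccc(S(=O)(=O)/C(=C/c2ccc(C)s2)C(=O)c2ccc(Cl)cc2)cc1` gives 50000 nM in this assay, and compound 3 `Cc1ccc(/C=C(\C(=O)c2ccc([N+](=O)[O-])cc2)S(=O)(=O)Cc2ccc(Cl)cc2)s1` gives 25000 nM. The two measured steps were both large: a 50-fold lower number from compound 1 to compound 2 (1.70 log units; beyond the scatter), and a 25-fold higher number from compound 2 to compound 3 (1.40 log units; beyond the scatter).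

Compound 4 `CCOc1cc(/C=C(\C(=O)c2ccc(Cl)cc2)S(=O)(=O)Cc2ccc(Cl)cc2)ccc1O` has not yet been measured. It differs from compound 2 at a single place: 3-ethoxy-4-hydroxyphenyl in place of 5-methylthiophen-2-yl on a double-bonded chain carbon bound to a double-bonded chain carbon. Neither of the measured steps touches this place; one concerns the group on a sulfonyl sulfur and the other a substituent on an aromatic carbon. So there is no direct guide to how this assay responds to a change on the double-bonded chain carbon. What the measured steps do show is that a single change elsewhere in this shared core moved the number sharply in both cases, so a change of this size, bringing in a 3-ethoxy-4-hydroxyphenyl group with its hydrogen-bond donor, is expected to move the number well beyond the scatter, and more likely upward than downward. The expected step is a 4.0-fold higher number from compound 2 to compound 4 (0.60 log units; beyond the scatter). Compound 4 is estimated at 4000 nM, with a range from 400 nM to 40000 nM.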

Compound 4, concentration for 50% growth inhibition: 10000 nM
For compound 4 the middle estimate is 2.5-fold (0.40 log units) below the measured one; the measured number falls inside the stated range.
By their numbers in this assay, from the lowest: compound 2; then compound 4; then compounds 3 and 1 (each within the scatter of the next).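

For the compounds shown here, this is the first measured change at this place, on a double-bonded chain carbon bound to a double-bonded chain carbon, and in this assay it gives a 10-fold higher number from compound 2 to compound 4 (1.00 log units; beyond the scatter), so the number responds to the group held here as well as to the two places changed earlier. The exchange takes out 5-methylthiophen-2-yl, a five-membered aromatic ring with a sulfur and no hydrogen-bond donor, and brings in 3-ethoxy-4-hydroxyphenyl, a six-membered ring of carbon only with a hydrogen-bond donor, so ring size, ring atoms, the ethoxy group and the hydroxy group all change in this one step, and the step cannot separate their shares. No measurement at hand accounts for the rise in the number.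

The compounds shown leave open how a plain phenyl group or a thiophene without its methyl would read at this place, either of which would help to separate the ring from its substituents. They also leave open whether a group carrying an amine or a carboxylic acid here would give a lower or a higher number than compound 2.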